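The source may report more compounds than this note shows. Statements on the series, on what has been measured and on what is new or still open speak of the compounds shown alone.

Compound 1 `O=C1c2c[n+]([O-])c3ccccc3c2C(=O)c2c1c1ccccc1n2Cc1cn([C@H]2O[C@H](CO)[C@@H](O)[C@H]2O)nn1`: 710 nM
Compound 2 `CCCCN1CCN(CCCCn2c3c(c4ccccc42)C(=O)c2c[n+]([O-])c4ccccc4c2C3=O)CC1`: 1920 nM
Compound 3 `CCCN1CCN(CCCCn2c3c(c4ccccc42)C(=O)c2c[n+]([O-])c4ccccc4c2C3=O)CC1`: 790 nM

These numbers come from a functional assay on HCT-116 cells (Homo sapiens) for cytotoxicity, read by MTT assay, with a stated time of 72 h; a lower number here means a stronger inhibitor, a higher number a weaker inhibitor. Compound 1 has the lowest number, but it lies within the usual scatter of compound 3, while compound 2 sits clearly higher.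

Compound 4 `O=C1c2c[n+]([O-])c3ccccc3c2C(=O)c2c1c1ccccc1n2Cc1cn([C@H]2C[C@H](O)[C@@H](CO)O2)nn1` carries 4-hydroxy-5-(hydroxymethyl)oxolan-2-yl in place of 3,4-dihydroxy-5-(hydroxymethyl)oxolan-2-yl on an aromatic nitrogen. Going by the values given here, no measured step touches this group. The only one, a 2.4-fold lower number from compound 2 to compound 3 (0.39 log units; beyond the scatter), swaps methyl for hydrogen on a saturated chain carbon elsewhere in the molecule, so it offers only a rough sense of scale: a modest step. A change beyond the scatter is therefore not expected here. The estimated outcome is a 1.1-fold higher number from compound 1 to compound 4 (0.05 log units; within the scatter). Compound 4 is expected at about 800 nM, with an estimated range of 300 nM to 2100 nM.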

Compound 4, half-maximal inhibitory concentration: 120 nM
For compound 4 the middle estimate is 6.7-fold (0.82 log units) above the measured one; the measured number lies below the stated range.
By their numbers in this assay, from the lowest: compound 4; then compounds 1 and 3 (each within the scatter of the next); then compound 2.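

Replacing 3,4-dihydroxy-5-(hydroxymethyl)oxolan-2-yl with 4-hydroxy-5-(hydroxymethyl)oxolan-2-yl on the aromatic nitrogen gives a 5.9-fold lower number from compound 1 to compound 4 (0.77 log units; beyond the scatter). Going by these compounds alone, this is the first measured step at this position, and it shows that cell potency here responds to a small edit: the two groups share the same five-membered non-aromatic ring and differ by a single hydroxy group. Nothing available explains why the number falls. Still open, going by these compounds, is whether a fluorine or an amine in place of that hydroxy group would give a similar number. The compounds shown also do not tell whether losing the remaining ring hydroxy group would lower it further.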